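The source may report more compounds than this note shows. Statements on the series, on what has been measured and on what is new or still open speak of the compounds shown alone.

In a functional assay on DU-145 cells (Homo sapiens) for antiproliferative activity, read by propidium iodide staining, with a stated time of 96 h (a higher number here means a weaker inhibitor, a lower number a stronger inhibitor), compound 1 `CC(O)(CSc1ccc(S(F)(F)(F)(F)F)cc1)C(=O)Nc1ccc(S(F)(F)(F)(F)F)cc1` gives 22300 nM and compound 3 `CC(O)(CSc1ccc(C(F)(F)F)cn1)C(=O)Nc1ccc(S(F)(F)(F)(F)F)cc1` gives 30700 nM. Compound 2 `CC(O)(CSc1ccc(F)cc1)C(=O)Nc1ccc(S(F)(F)(F)(F)F)cc1`, at 25400 nM, stands in the middle of these numbers, within the scatter of both. Compound 4 `CC(O)(COc1ccc(C#N)cc1)C(=O)Nc1ccc(S(F)(F)(F)(F)F)cc1`, not yet measured, carries 4-cyanophenoxy in place of (4-fluorophenyl)sulfanyl on a saturated chain carbon (4-cyanophenoxy in place of (4-fluorophenyl)sulfanyl on a saturated chain carbon, two bonds along the chain from a carbonyl carbon and an oxygen on a saturated carbon). Two measured steps changed the aromatic group on sulfur, and both were small: a 1.1-fold higher number from compound 1 to compound 2 (0.06 log units; within the scatter) and a 1.2-fold higher number from compound 2 to compound 3 (0.08 log units; within the scatter). Going by these compounds, neither step replaces sulfur with oxygen, so that part of the change is untested. No step beyond the scatter is therefore expected in this assay. The expected change is a 1.1-fold higher number from compound 2 to compound 4 (0.04 log units; within the scatter). For compound 4 the estimate is 28000 nM, with an expected range from 12000 nM to 65000 nM.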

Compound 4, half-maximal inhibitory concentration: 32200 nM
Compound 4: middle estimate off by 1.2-fold (0.06 log units), on the low side, and the stated range covers the measured number.
By their numbers in this assay, from the lowest: compounds 1, 2, 3 and 4 (each within the scatter of the next).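

In this assay, 4-cyanophenoxy in place of (4-fluorophenyl)sulfanyl gives a 1.3-fold higher number from compound 2 to compound 4 (0.10 log units; within the scatter), so a change that includes swapping sulfur for oxygen still leaves the number within the scatter. This one step alters both the linking atom and the ring's substituent, so their separate contributions cannot be told apart, and they may offset each other. No measurement shown explains this result.

All four compounds carry an aromatic ring linked through sulfur or oxygen. An amine as the link, or a longer chain before the ring, could show whether changes at this place ever move the number beyond the scatter.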